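The source may report more compounds than this note shows. Statements on the series, on what has been measured and on what is new or still open speak of the compounds shown alone.

Working notes on the series, read in a functional assay on A2780 cells (Homo sapiens) for inhibition; on this read-out lower numbers stand for stronger inhibition and higher numbers for weaker inhibition. Compound 3 `CCCN(CCC)Cc1cc(-c2c(C(=O)NCC)noc2-c2cc(C(C)C)c(O)cc2O)on1` has no number to stand on, and its entry reads "not determined" (no result reported). Compound 1 `CCNC(=O)c1noc(-c2cc(C(C)C)c(O)cc2O)c1-c1cc(COCC(N)=O)no1` is in the same situation, with "not determined" (no result reported). The only numerical result comes from compound 2 `C=CNCc1cc(-c2c(C(=O)NCC)noc2-c2cc(C(C)C)c(O)cc2O)on1`, which gives 43 nM.

Still unmeasured is compound 4 `CCNC(=O)c1noc(-c2cc(C(C)C)c(O)cc2O)c1-c1cc(C(N)=O)no1`, which carries carbamoyl in place of (dipropylamino)methyl on an aromatic carbon of a five-membered aromatic ring with 1 nitrogen and 1 oxygen: carbamoyl in place of (dipropylamino)methyl on an aromatic carbon. Among the measured compounds shown here, no measured step shows what a change at this place does, and compound 3 offers no starting value, so the size and direction of a step from it cannot be read from the data. The working expectation is therefore anchored on compound 2 at 43 nM, with no shift beyond the scatter expected from that level, though the uncertainty is wide with a single number behind it. Compound 4 is expected at 40 nM, with an estimated range of 12 nM to 150 nM.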

Compound 4, half-maximal inhibitory concentration: 15 nM
Compound 4: middle estimate off by 2.7-fold (0.43 log units), on the high side; the range from low to high includes it.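

In this assay, this position on the five-membered aromatic ring now has its first readable step: carbamoyl in place of (vinylamino)methyl gives a 2.9-fold lower number from compound 2 to compound 4 (0.46 log units; beyond the scatter). In this pair, an amine nitrogen in the side chain is not needed for inhibition at this level, and a carbamoyl set directly on the aromatic carbon is accepted with a modest gain. The data at hand offer no explanation for this step. Among the compounds shown here, compound 1 and compound 3 have no single number, so no step from either can be read, and the effect of the (dipropylamino)methyl group remains unknown. Going by these compounds, it also remains open whether a carboxylic acid, a nitrile or a dimethylcarboxamide at the same carbon would keep this level of inhibition.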